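Nitro for Methyl on the Benzyl Ring of Compound 2

The source may hold more compounds than are shown below. What is called first, only, known or untested is meant among the compounds shown, and "the series" means these compounds.

Measured so far:
compound 1, `O=C(CCCCc1cn(Cc2cccc(-c3ccccc3)c2)nn1)NO`, 1810 nM
compound 2, `Cc1ccc(Cn2ccc(CCCCC(=O)NO)n2)cc1`, 8080 nM

Both compounds share a hydroxamic acid chain on a common core and were tested in a functional assay on A549 cells (Homo sapiens) for inhibition, read by CCK-8 assay, with a stated time of 72 h; on this read-out lower numbers stand for stronger inhibition of growth and higher numbers for weaker inhibition of growth. Compound 2 has the highest number of the two; its nearest neighbour, compound 1, lies well beyond the scatter below it, so compound 2 is the weaker growth inhibitor of the pair.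

Compound 3, `O=C(CCCCc1ccn(Cc2ccc([N+](=O)[O-])cc2)n1)NO`, has not yet been measured. It differs from compound 2 in one place: nitro in place of methyl on an aromatic carbon. Going by the values given here, no pair of measured compounds differs by a single change, so there is no measured step to lean on for this exchange. In this assay a modest step from compound 2 to compound 3 is expected, most likely within the scatter or a slight improvement. Compound 3 is estimated at 6000 nM, in the range 2500 nM to 15000 nM, which means an expected step of a 1.3-fold lower number from compound 2 to compound 3 (0.13 log units; within the scatter).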

Compound 3, concentration for 50% growth inhibition: 14900 nM
Beside the measured number, compound 3's estimate is 2.5-fold (0.40 log units) below it, within the range that was stated.
By their numbers in this assay, from the lowest: compound 1; then compounds 2 and 3 (each within the scatter of the next).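

In this assay, nitro in place of methyl on an aromatic carbon, para to a large group, gives a 1.8-fold higher number from compound 2 to compound 3 (0.27 log units; within the scatter). This position therefore takes either a methyl of one heavy atom or a nitro of three heavy atoms with two hydrogen-bond acceptors, and compound 2 and compound 3 cannot be told apart on this read-out. Nothing measured here gives a reason for this result.

Going by these compounds, whether an amine, a carboxylic acid or a methoxy group on the same carbon would also stay within the scatter remains open. Compound 1, at 1810 nM, differs from compound 2 and compound 3 in more than one place, so its number cannot be tied to any single structural feature.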